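The source may report more compounds than this note shows. Statements on the series, on what has been measured and on what is new or still open speak of the compounds shown alone.

Measured so far:
compound 1 `CCc1cc(C(C)=O)c(O)cc1OCCCCCC(C)(C)C#N`, 17%
compound 2 `CCc1cc(C(C)=O)c(O)cc1OCCCCCCC(C)(C)C#N`, 11%
compound 3 `CCc1cc(C(C)=O)c(O)cc1OCCCCCCCC(C)(C)C#N`, 6%

All three values come from an assay on isolated protein for binding affinity to leukotriene B4 receptor (Homo sapiens), tested at 0.1 uM; on this read-out higher numbers stand for more inhibition at the one concentration tested (going by the name of the read-out) and lower numbers for less inhibition. Compound 2 stands second highest of the three, within the scatter of both compound 3 and compound 1. Compound 4 `CCc1cc(C(C)=O)c(O)cc1OCCCC(C)(C)c1nnn[nH]1` is the next step: 1-(1H-tetrazol-5-yl)-1-methylethyl in place of 4-cyano-4-methylpentyl on a saturated chain carbon, three bonds along the chain from an oxygen on an aromatic ring. The measured steps change only chain length: a number 6 percentage points lower from compound 1 to compound 2 (within the scatter), a number 5 percentage points lower from compound 2 to compound 3 (within the scatter), and a number 11 percentage points lower from compound 1 to compound 3 (beyond the scatter), the shorter chain giving the higher number. On these data alone, none of them swaps the nitrile for a tetrazole, so the new group is untested here. Shortening alone would suggest a small rise; the tetrazole is unknown. Compound 4 is therefore estimated at 30%, with a wide range from 5% to 70%, which means an expected step of a number 19 percentage points higher from compound 2 to compound 4 (beyond the scatter) in this assay.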

Compound 4, a percentage reported as inhibition, at one concentration (the size of the read-out at that concentration, not a potency): 28%
The estimate for compound 4 lay 2 percentage points above the measured number; the range from low to high includes it.
By their numbers in this assay, from the lowest: compounds 3, 2 and 1 (each within the scatter of the next, the first and the last beyond it); then compound 4.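

In this assay, the change to 1-(1H-tetrazol-5-yl)-1-methylethyl gives a number 17 percentage points higher from compound 2 to compound 4 (beyond the scatter) and a number 11 percentage points higher from compound 1 to compound 4 (beyond the scatter), so a nitrile at the chain end is not required for inhibition at this one concentration. Each step also alters the chain between the aromatic oxygen and the end group, so the two changes cannot be separated. No measurement available here accounts for the rise.

On these data alone, it remains open whether the tetrazole ring or the shorter chain matters more. A carboxylic acid on the same short chain, or a tetrazole on a longer chain, would help to settle this.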